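From an Open Amino Alcohol to a Hydroxylated Ring

A few compounds are considered here, and "the series" means these few. Any claim that something is new, unique, unknown or untested is made for them only; others in the source may bear on it.

Among the measured compounds shown here, in a functional assay on HeLa cells (Homo sapiens) for antiproliferative activity, read by CCK-8 assay, with a stated time of 48 h (on this read-out lower numbers stand for stronger inhibition and higher numbers for weaker inhibition), compound 3 `COc1ccc(/C=C\c2cc(OC)c(OC)c(OC)c2)cc1OCc1ccc(CNCCO)cc1` gives 4400 nM, the lowest number measured so far. Compound 2 `COc1ccc(/C=C\c2cc(OC)c(OC)c(OC)c2)cc1OCc1ccc(CN2CCCCC2C(=O)O)cc1` gives 14200 nM. Compound 1 `COc1ccc(/C=C\c2cc(OC)c(OC)c(OC)c2)cc1OCc1ccc(CNC(C)(C)C(=O)O)cc1` reads > 10000 nM, which is a limit of the assay.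

Compound 4 `COc1ccc(/C=C\c2cc(OC)c(OC)c(OC)c2)cc1OCc1ccc(CN2CC[C@H](O)C2)cc1` differs from compound 3 as follows: 3-hydroxypyrrolidin-1-yl in place of (2-hydroxyethyl)amino on a saturated chain carbon bound to an aromatic carbon. The nearest evidence is a 3.2-fold lower number from compound 2 to compound 3 (0.51 log units; beyond the scatter) and an at least 2.2-fold lower number from compound 1 to compound 3 (0.35 log units; beyond the scatter). For the measured compounds named here, both steps lead to the (2-hydroxyethyl)amino group from carboxy-bearing groups, while compound 4 carries no carboxy group, and no measured compound tests the 3-hydroxypyrrolidin-1-yl group. In this assay, the expected step is a 1.3-fold lower number from compound 3 to compound 4 (0.10 log units; within the scatter), which is not expected to exceed the scatter. For compound 4, the estimated value is 3500 nM, with an expected range of 1200 nM to 10000 nM.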

Compound 4, half-maximal inhibitory concentration: 10500 nM
Estimate against measurement, compound 4: 3.0-fold (0.48 log units) below, outside the stated range (above it).
By their numbers in this assay, from the lowest: compound 3; then compounds 4 and 2 (each within the scatter of the next).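

In this assay, closing the open (2-hydroxyethyl)amino chain into the 3-hydroxypyrrolidin-1-yl ring gives a 2.4-fold higher number from compound 3 to compound 4 (0.38 log units; beyond the scatter), so on this saturated chain carbon bound to an aromatic carbon, a group without a carboxy group can also read higher than compound 3. The ring also shows a 1.4-fold lower number from compound 2 to compound 4 (0.13 log units; within the scatter), which leaves the two without a separation. Compound 1 stands at a limit of the assay, and its step cannot be read: the limit of > 10000 nM in this assay, at which 1 of the 4 values shown sits.

As far as these compounds go, whether a morpholin-4-yl or 4-hydroxypiperidin-1-yl group would read nearer to compound 3 stays open. So does the outcome for the opposite configuration at the stereocentre of the ring.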